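Compound 3 to compound 4: a change at the chain end

A few compounds are considered here, and "the series" means these few. Any claim that something is new, unique, unknown or untested is made for them only; others in the source may bear on it.

Measured in an ADME assay on BJ cells (Homo sapiens) for cytotoxicity, with a stated time of 72 h; a higher number here means that more compound is needed for the effect, a lower number that less compound is needed
compound 1 `C=C[C@@](C)(/C=C/c1ccc(OC)cc1)CCC=C(C)C` gives > 36600 nM
compound 2 `C=C[C@@](C)(/C=C/c1ccc(OCc2ccccc2)cc1)CCC=C(C)C` gives > 36600 nM
compound 3 `C=C[C@@](C)(/C=C/c1ccc(O)cc1)CCC1OC1(C)C` gives > 36600 nM

Each of these entries is a limit and not a number. Compound 3 gives only a limit (> 36600 nM) and so offers no number to start from. Within the data shown here, the whole set sits together at one value (the limit of > 36600 nM in this assay, at which 3 of the 3 values shown sit) with no spread among the compounds.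

Compound 4 `C=C[C@@](C)(/C=C/c1ccc(O)cc1)CCCO` has not yet been measured. It differs from compound 3 as follows: hydroxymethyl in place of 3,3-dimethyloxiran-2-yl on a saturated chain carbon, three bonds along the chain from two double-bonded chain carbons. Among the measured compounds shown here, the only measured step (a step that the two limits leave unreadable from compound 1 to compound 2) is a different change and gives no size to carry over. No step beyond the usual scatter can therefore be expected in this assay, and no direction can be named. The estimated change (a step that the limit leaves unreadable from compound 3 to compound 4) is accordingly expected to be unreadable or small. For compound 4 the expected value is 40000 nM, with an estimated range from 20000 nM to 80000 nM, and a reported limit is the likeliest outcome.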

Compound 4, half-maximal effective concentration: > 36600 nM
Compound 4 ended at the assay's limit; the forecaster's own chance of this, stated with the estimate: 85%; the middle value does not contradict the limit.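

No step can be read between compound 3 and compound 4 in this assay, as both entries are limits and not numbers: the limit of > 36600 nM in this assay, at which 4 of the 4 values shown sit.

The compounds shown leave open whether any change to the shared core gives a measurable value in this assay, and how large any step would be.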